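This account rests on a few compounds, and the source may have more. Where it says the series, first, only, none or still open, it means among the compounds named here.

In a functional assay on MCF7 cells (Homo sapiens) for antiproliferative activity, read by CellTiter-Glo, with a stated time of 5 days (on this read-out lower numbers stand for stronger inhibition and higher numbers for weaker inhibition), compound 1 (`CC1=C(c2cccc(O)c2)C(c2ccc(OC[C@@H](C)N3CCCC3)cc2)Oc2ccc(O)cc21`) gives 0.2 nM, while compound 2 (`CC1=C(c2cccc(O)c2)[C@@H](c2ccc(OC[C@H](C)N3CC[C@@H](C)C3)cc2)Oc2ccc(O)cc21`) gives 59 nM, the higher of the two numbers and beyond the scatter. Compound 3 (`CC1=C(c2cccc(O)c2)C(c2ccc(OC[C@@H](C)N3CC[C@@H](C)C3)cc2)Oc2ccc(O)cc21`) has the same atoms and bonds as compound 2: the two compounds have the same atoms and bonds; at least one stereo element is drawn with a configuration in one of them and without one in the other: 2 of 3 stereo elements differ; a stereocentre at a saturated ring carbon is drawn R in compound 2 and without a configuration in compound 3; a stereocentre at a saturated chain carbon is drawn S in compound 2 and R in compound 3. A stereocentre at a saturated chain carbon is drawn S in compound 2 and R in compound 3, and a stereocentre at a saturated ring carbon is drawn R in compound 2 and without a configuration in compound 3. For the measured compounds named here, no measured pair isolates this change, so the expectation leans on compound 1 at 0.2 nM. In this assay a large fall beyond the scatter is expected, a 74-fold lower number from compound 2 to compound 3 (1.87 log units; beyond the scatter). For compound 3 the estimated value is 0.8 nM, with an expected range of 0.15 nM to 6 nM.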

Compound 3, half-maximal inhibitory concentration: 0.2 nM
Compound 3: the middle estimate sits 4.0-fold (0.60 log units) above what was measured; measured number inside the range.
By their numbers in this assay, from the lowest: compounds 1 and 3 (each within the scatter of the next); then compound 2.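

With atoms and bonds unchanged, stereochemistry alone gives a 300-fold lower number from compound 2 to compound 3 (2.47 log units; beyond the scatter) in this assay. With the chain carbon drawn R, methyl in place of hydrogen on a saturated ring carbon gives no change at the digits printed from compound 1 to compound 3 (within the scatter). How much of the first step belongs to the chain carbon and how much to the ring carbon stays unassigned, and one fact limits the reading: the fact that one of compounds 2 and 3 is drawn with a defined configuration and the other without, at the place where they differ

Still open, going by these compounds, is how each defined configuration at the ring carbon behaves when the chain carbon is drawn R. Also open is whether a piperidine or a dimethylamino group on the chain gives a number like those of compound 1 and compound 3.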